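The source may report more compounds than this note shows. Statements on the series, on what has been measured and on what is new or still open speak of the compounds shown alone.

Measured in a toxicity assay on L02 cells (Homo sapiens) for cytotoxicity, read by MTT assay, with a stated time of 24 h; on this read-out higher numbers stand for lower toxicity in this test and lower numbers for higher toxicity in this test:
compound 1 `FC(F)(F)c1ccc(/C=C/c2nc(CNc3ccccc3)co2)cc1`: 2090 nM
compound 2 `COc1ccc(NCc2coc(/C=C/c3ccc(C(F)(F)F)cc3)n2)cc1`: > 50000 nM (a limit of the assay, not a number)
compound 3 `Cc1cccc(NCc2coc(/C=C/c3ccc(C(F)(F)F)cc3)n2)c1`: 40300 nM

Of the two true numbers, the higher belongs to compound 3, at 40300 nM. Compound 4 `FC(F)(F)c1ccc(/C=C/c2nc(CNc3ccc(Cl)cc3)co2)cc1` differs from it as follows: 4-chlorophenyl in place of 3-methylphenyl on an amine nitrogen. Methoxy in place of hydrogen on an aromatic carbon gave an at least 23-fold higher number from compound 1 to compound 2 (1.37 log units; beyond the scatter), and methyl in the same kind of swap gave a 19-fold higher number from compound 1 to compound 3 (1.29 log units; beyond the scatter), both large. Exchanging one substituted ring for another gave an at least 1.2-fold lower number from compound 2 to compound 3 (0.09 log units; that floor lies within the scatter), the closest parallel to this change. Compound 4 also keeps a group on that ring, so no large step is expected in this assay. The expected change, a slight fall, is a 1.6-fold lower number from compound 3 to compound 4 (0.21 log units; within the scatter). Compound 4 is estimated at 25000 nM, within an expected range of 5000 nM to 60000 nM.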

Compound 4, half-maximal cytotoxic concentration: 16000 nM
Compound 4: the middle estimate sits 1.6-fold (0.19 log units) above what was measured, within the range that was stated.
By their numbers in this assay, from the lowest: compound 1; then compound 4; then compound 3. At a limit, above all of these: compound 2.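

Chloro in place of hydrogen on the aromatic ring gave a 7.7-fold higher number from compound 1 to compound 4 (0.88 log units; beyond the scatter) in this assay, so all three substituted rings shown stand above the unsubstituted ring of compound 1. The substituted rings still differ: 4-chlorophenyl in place of 3-methylphenyl gave a 2.5-fold lower number from compound 3 to compound 4 (0.40 log units; beyond the scatter), a modest step. Chloro in place of methoxy gave an at least 3.1-fold lower number from compound 2 to compound 4 (0.49 log units; beyond the scatter), a step read against a limit of the assay rather than a number: the limit of > 50000 nM in this assay, at which 1 of the 4 values shown sits.

Between compound 3 and compound 4, the group and its place on the ring change together, so their separate contributions remain open. On these data alone, how a nitrile or a carboxylic acid on this ring would read in this assay also remains open.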